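This account rests on a few compounds, and the source may have more. Where it says the series, first, only, none or still open, it means among the compounds named here.

Measured in an ADME assay on HEp-2 cells (Homo sapiens) for cytotoxicity; a higher number here means that more compound is tolerated, a lower number that less compound is tolerated:
- compound 1 `CCc1cc2ccccc2n(Cc2nc3ccccc3n2CCCCF)c1=O`: 85100 nM
- compound 2 `CN1C(=O)N(Cc2nc3ccccc3n2CCCCF)c2ccccc2S1(=O)=O`: 87700 nM
- compound 3 `CN1C(=O)N(Cc2nc3ccccc3n2CCCS(C)(=O)=O)c2ccccc2S1(=O)=O`: 34500 nM

Compound 3 stands lowest of the three in this assay. Compound 4 `CN1C(=O)N(Cc2nc3ccccc3n2CCCCO)c2ccccc2S1(=O)=O` differs from compound 3 by one change: hydroxymethyl in place of methylsulfonyl on a saturated chain carbon, three bonds along the chain from an aromatic nitrogen. Among the compounds with values here, only one measured step bears on this, a 2.5-fold lower number from compound 2 to compound 3 (0.41 log units; beyond the scatter), which put methylsulfonyl in place of fluoromethyl at the same place on the chain. Within the data shown here, compound 4 removes that methylsulfonyl again, but no measured compound carries hydroxymethyl, so a return to the level of compound 2 is only a guide. A modest rise of about the same size or smaller is therefore expected, and the estimated change is a 1.8-fold higher number from compound 3 to compound 4 (0.25 log units; within the scatter). For compound 4 the estimated value is 62000 nM, with an expected range from 28000 nM to 120000 nM.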

Compound 4, half-maximal cytotoxic concentration: 219000 nM
For compound 4 the middle estimate is 3.5-fold (0.55 log units) below the measured one; measured number above the stated range.
By their numbers in this assay, from the lowest: compound 3; then compounds 1 and 2 (each within the scatter of the next); then compound 4.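

In this assay, replacing methylsulfonyl with hydroxymethyl at this place on the chain gives a 6.3-fold higher number from compound 3 to compound 4 (0.80 log units; beyond the scatter) and so does more than reverse the earlier fall. Hydroxy in place of fluoro gives a 2.5-fold higher number from compound 2 to compound 4 (0.40 log units; beyond the scatter) and shows that the level of compound 2 is not the ceiling for this chain. No available evidence bears on the reason for this rise. The compounds shown leave open whether an amine, a carboxylic acid or a longer chain carrying hydroxy would behave alike. On these data alone, whether hydroxy has the same effect on the core of compound 1 also remains open.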